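The source may hold more compounds than are shown below. What is called first, only, known or untested is meant among the compounds shown, and "the series" means these compounds.

compound 1 `Cc1ccc(S(=O)(=O)c2nc3ccccc3nc2N2CCCC2)cc1`: > 50000 nM
compound 2 `O=S(=O)(c1ccc(Br)cc1)c1nc2ccccc2nc1N1CCCC1`: 37700 nM
compound 3 `O=S(=O)(c1ccc(F)cc1)c1nc2ccccc2nc1N1CCCC1`: 20600 nM

In a functional assay on HCT-116 cells (Homo sapiens) for cytotoxicity, read by MTT assay, with a stated time of 72 h (on this read-out lower numbers stand for stronger inhibition and higher numbers for weaker inhibition), compound 1 stands at > 50000 nM, which is a limit and not a number.

The unmeasured compound 4 `Cc1ccc(S(=O)(=O)c2nc3ccccc3nc2N2CCc3ccccc3C2)cc1` keeps the rest of compound 1 and changes one group: 1,2,3,4-tetrahydroisoquinolin-2-yl in place of pyrrolidin-1-yl on an aromatic carbon. The entering 1,2,3,4-tetrahydroisoquinolin-2-yl brings a six-membered aromatic ring of carbon only, which pyrrolidin-1-yl lacks.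

All three measured compounds carry pyrrolidin-1-yl and differ only in methyl, bromo or fluoro on an aromatic carbon. Going by the values given here, no measured step therefore tests this exchange directly, and those steps serve only as a rough guide to size. They are an at least 1.3-fold lower number from compound 1 to compound 2 (0.12 log units; that floor lies within the scatter), an at least 2.4-fold lower number from compound 1 to compound 3 (0.38 log units; beyond the scatter) and a 1.8-fold lower number from compound 2 to compound 3 (0.26 log units; within the scatter). These are small steps, and the two that start from compound 1 rest on its limit.

On that guide, a modest move toward lower numbers is expected, similar in size to an at least 2.4-fold lower number from compound 1 to compound 3 (0.38 log units; beyond the scatter), though compound 4 could also stay at the limit. The expected step is an at least 2.2-fold lower number from compound 1 to compound 4 (0.35 log units; beyond the scatter). Compound 4 is estimated at 22000 nM, with an expected range from 8000 nM to 50000 nM.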

Compound 4, half-maximal inhibitory concentration: 39000 nM
Compound 4: middle estimate off by 1.8-fold (0.25 log units), on the low side, within the range that was stated.
By their numbers in this assay, from the lowest: compounds 3, 2 and 4 (each within the scatter of the next). At a limit, above all of these: compound 1.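

In this assay, compound 4 is the first compound shown with a change at the aromatic carbon next to the ring nitrogen, where 1,2,3,4-tetrahydroisoquinolin-2-yl brings in a six-membered aromatic ring of carbon only, and the result is an at least 1.2-fold lower number from compound 1 to compound 4 (0.10 log units; that floor lies within the scatter). Compound 1 stands at > 50000 nM, which is a limit and not a number. The step from pyrrolidin-1-yl is therefore only a floor, and its true size stays unknown because one end of it rests on that limit: the limit of > 50000 nM in this assay, at which 1 of the 4 values shown sits.

The compounds shown leave open whether any difference at this position comes from the added aromatic ring or from the change to a six-membered non-aromatic ring, a question that piperidin-1-yl, which has the second without the first, could help to separate. Going by these compounds, it also remains open whether the tetrahydroisoquinolin-2-yl group would give a similar step with fluoro or bromo in place of methyl, and whether an open-chain amine such as dimethylamino would be read in this assay at a number or at the limit.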